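Removing a Methyl from Compound 1: What to Expect

This account rests on a few compounds, and the source may have more. Where it says the series, first, only, none or still open, it means among the compounds named here.

Three compounds have been measured so far:
- compound 1, `Cc1nc(-c2ccccc2NCC2=NCCN2)n(C)n1`, 98%
- compound 2, `CCn1cc(-c2ccccc2NCC2=NCCN2)cn1`, 0%
- compound 3, `CCn1nccc1-c1ccccc1NCC1=NCCN1`, 81%

All three share a core and were tested in a functional assay with Alpha-1A adrenergic receptor (Homo sapiens) as the target, read by calcium flux; on this read-out higher numbers stand for larger maximal responses and lower numbers for smaller maximal responses. Compound 1 gives the highest of the three numbers. Its nearest neighbour is compound 3, whose number is lower by a margin beyond the usual scatter. Compound 2 stands furthest away, with a number far below that of compound 1. Without any single-point steps among the measured compounds, no measured change of this exact kind is available for comparison.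

The compound now in question is compound 4, `Cn1ncnc1-c1ccccc1NCC1=NCCN1`. It differs from compound 1 only in this: hydrogen in place of methyl on an aromatic carbon. The group that leaves is small, carries no ring and no donors or acceptors, so the change is modest in scale.

Compound 4 is expected to remain a strong responder, with an estimated step of a number 13 percentage points lower from compound 1 to compound 4 (beyond the scatter) relative to compound 1. The estimated value for compound 4 is 85%, within a range from 55% to 105%.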

Compound 4, largest response reached (reported as maximal response), in percent of the reference or control that the assay uses: 91%
Estimate against measurement, compound 4: 6 percentage points below; measured number inside the range.
By their numbers in this assay, from the lowest: compound 2; then compounds 3, 4 and 1 (each within the scatter of the next, the first and the last beyond it).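

Going by these compounds alone, compound 1 and compound 4 are the first pair here that differ in only one place, so this is the first direct reading of what the methyl on this aromatic carbon contributes. In this assay the pair gives a number 7 percentage points lower from compound 1 to compound 4 (within the scatter) as the step for hydrogen in place of methyl, which means the two compounds cannot be told apart on this read-out. In this pair, then, a large maximal response does not depend on that methyl, and no measurement shown here explains the result.

The compounds shown leave open what a bigger or differently built group would do on this same carbon, such as an amine, a carboxylic acid or a longer chain like propyl. They also leave open whether the tolerance seen for methyl and hydrogen extends to any such group.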